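Chloro for bromo on the fused ring of compound 3

This account rests on a few compounds, and the source may have more. Where it says the series, first, only, none or still open, it means among the compounds named here.

Compound 1 `COc1ccc(C2=NN(C3=NC(=O)/C(=C4\C(=O)Nc5ccc(Br)cc54)S3)C(c3ccc(Cl)cc3)C2)cc1` gives 14700 nM in a functional assay on cells (Cancer cell lines, Homo sapiens) for cytotoxicity, read by sulforhodamine B assay, with a stated time of 48 h; a higher number here means a weaker inhibitor of growth, a lower number a stronger inhibitor of growth. Compound 2 `CN(C)c1ccc(C2CC(c3ccccc3)=NN2C2=NC(=O)/C(=C3\C(=O)Nc4ccccc43)S2)cc1` gives 39700 nM in this assay. Compound 3 `COc1ccc(-c2cc(-c3ccc(Cl)cc3)n(C3C(=O)Nc4ccc(Br)cc43)n2)cc1` gives 28700 nM in this assay; its number lies between the other two, and both gaps, to compound 2 and to compound 1, fall within the scatter of the method, so no ranking among the three is supported.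

Compound 4 `COc1ccc(-c2cc(-c3ccc(Cl)cc3)n(C3C(=O)Nc4ccc(Cl)cc43)n2)cc1` is not yet measured. It differs from compound 3 by chloro in place of bromo on an aromatic carbon, a chloro in place of bromo on an aromatic carbon of the fused ring. Among the compounds with values here, no pair of measured compounds shows this single change, so there is no step to lean on. With one halogen replaced by another at the same place and no change in count of donors or acceptors, the expectation is for no step beyond the scatter in this assay, in either direction.

Compound 4 is therefore expected to give about 30000 nM in this assay, within a range of 12000 nM to 70000 nM. That estimate means a step of a 1.0-fold higher number from compound 3 to compound 4 (0.02 log units; within the scatter), expected to be within the scatter.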

Compound 4, concentration for total growth inhibition: 14700 nM
Estimate against measurement, compound 4: 2.0-fold (0.31 log units) above; the measured number falls inside the stated range.
By their numbers in this assay, from the lowest: compounds 1, 4, 3 and 2 (each within the scatter of the next, the first and the last beyond it).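

In this assay, within the data shown here, the only single-place step reads a 2.0-fold lower number from compound 3 to compound 4 (0.29 log units; within the scatter), so chloro in place of bromo on this aromatic carbon of the fused ring leaves the number within the scatter of the method. Among these compounds, for these two compounds, either halogen at this position gives a reading that cannot be told apart from the other, which the earlier compounds, with no single-place pair among them, could not show. No measurement bearing on the reason for this outcome is available.

On these data alone, whether an amine or a carboxylic acid on this aromatic carbon would move the number beyond the scatter remains open. Also open, as far as these compounds go, is whether the same exchange of halogens gives a similar reading on the core of compound 1, which also carries bromo on its fused ring.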